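Swapping bromo for methyl on a sulfonyl-bearing bicyclic core

A few compounds are considered here, and "the series" means these few. Any claim that something is new, unique, unknown or untested is made for them only; others in the source may bear on it.

Measured so far in a functional assay on the whole organism for inhibition, with Mus musculus as the target, with a stated time of 5 h, at a dose of 50 mg/kg by the oral route; a higher number here means more inhibition at the dose given (going by the name of the read-out), a lower number less inhibition:
compound 1 `Cc1ccc(-c2c(S(=O)(=O)c3ccccc3)cnc3ncnn23)cc1` gives 2.4%;
compound 2 `O=S(=O)(c1ccccc1)c1cnc2ncnn2c1-c1ccc(Br)cc1` gives 0.8%;
compound 3 `Cc1ccc(-c2c(S(=O)(=O)c3ccccc3)cnc3cc(-c4ccc(Br)cc4)nn23)cc1` gives 31.7%.

Compound 1 and compound 2 share a core and differ by one change, (methyl in place of bromo on an aromatic carbon). The step that goes with it, a number 1.6 percentage points higher from compound 2 to compound 1 (within the scatter), is small, and the two numbers lie within the scatter of each other, so neither can be called higher than the other. Compound 3 carries a larger core than compound 2; the difference between the two cores is not broken down here. In this assay compound 3 stands clearly apart from both compound 1 and compound 2, with its steps to each of them beyond the scatter, so among the three measured compounds its number is the highest.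

Compound 4 `Cc1ccc(-c2cc3ncc(S(=O)(=O)c4ccccc4)c(-c4ccc(C)cc4)n3n2)cc1` has not yet been measured. It differs from compound 3 by methyl in place of bromo on an aromatic carbon, and the place of the change reads the same word for word as for the pair compound 2 and compound 1, so this is the same change. Because the earlier instance gave only a number 1.6 percentage points higher from compound 2 to compound 1 (within the scatter), a step of similar size is expected here, and the expected step is a number 2.3 percentage points higher from compound 3 to compound 4 (within the scatter). Compound 4 is therefore estimated to give 34%, with a likely range from 15% to 55%.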

Compound 4, a percentage reported as inhibition, in the whole organism at one dose (the size of the read-out at that dose, not a potency): 17%
Compound 4: the middle estimate sits 17 percentage points above what was measured; the range from low to high includes it.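

In this assay, the swap from 4-bromophenyl to 4-methylphenyl gives a number 14.7 percentage points lower from compound 3 to compound 4 (beyond the scatter), so this change cannot be assumed to have the same outcome on both cores. Setting the two instances side by side makes this plain: the same change on two cores in this assay, a number 1.6 percentage points higher (within the scatter) from compound 2 to compound 1 and a number 14.7 percentage points lower (beyond the scatter) from compound 3 to compound 4, 16.3 percentage points apart, beyond the scatter of two such steps. This shows that the near-silent result on the smaller core was a poor guide to the result on the larger one, but it does not show why the two differ, and two pairs are too few to give a rule for how the swap would behave on a third core.

The compounds shown also leave open whether the gap between compound 3 and compound 4 is specific to bromo and methyl, or whether other groups in the same place, such as chloro, methoxy or an amine, would give numbers closer to compound 3 or to compound 4. Going by these compounds, it also remains open how these compounds would compare at other doses or times, since each number here is the size of the read-out at a single dose and not a measure of potency.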